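Ester for amide on the aryl carbonyl of compound 2

The source may hold more compounds than are shown below. What is called first, only, known or untested is meant among the compounds shown, and "the series" means these compounds.

The series shares the core of compound 1 `NC(=O)CCCN(Cc1cccc(C(N)=O)c1)C[C@H]1O[C@@H](n2cnc3c(N)ncnc32)[C@H](O)[C@@H]1O`; compound 2 `NC(=O)CCCCN(Cc1cccc(C(N)=O)c1)C[C@H]1O[C@@H](n2cnc3c(N)ncnc32)[C@H](O)[C@@H]1O` carries a carbamoylmethyl group in place of the carbamoyl on the chain, and compound 3 `NC(=O)c1cccc(CN(CCCC(=O)O)C[C@H]2O[C@@H](n3cnc4c(N)ncnc43)[C@H](O)[C@@H]2O)c1` carries a carboxy group there. In an assay on cells for inhibition of Nicotinamide N-methyltransferase (Homo sapiens), with stated times of 10 min and 30 min (a higher number here means a weaker inhibitor, a lower number a stronger inhibitor), compound 1 gives only a limit of the assay, > 250000 nM. In this assay compound 2 likewise gives only a limit, > 250000 nM. In this assay compound 3 also gives only a limit, > 250000 nM. Compound 2 thus stands at the limit of > 250000 nM in this assay, at which 3 of the 3 values shown sit, together with every other measured compound. The steps a step that the two limits leave unreadable from compound 1 to compound 2, a step that the two limits leave unreadable from compound 1 to compound 3 and a step that the two limits leave unreadable from compound 2 to compound 3 are all unreadable in size, since each pair sits at the limit of > 250000 nM in this assay, at which 3 of the 3 values shown sit.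

Compound 4 `COC(=O)c1cccc(CN(CCCCC(N)=O)C[C@H]2O[C@@H](n3cnc4c(N)ncnc43)[C@H](O)[C@@H]2O)c1` differs from compound 2 by methoxy in place of amino on a carbonyl carbon. Among the compounds with values here, none of the measured steps touches the carbonyl on the aromatic ring, and none has a readable size, so they bear on this step only in showing that the whole series so far sits at the limit. The step that the limit leaves unreadable from compound 2 to compound 4 is therefore expected to be without readable direction. Compound 4 is expected to give 300000 nM, within 100000 nM to 1000000 nM, most probably again as a limit only.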

Compound 4, half-maximal inhibitory concentration: > 250000 nM
Compound 4: only a limit was reported (the forecaster's own chance of this, stated with the estimate: 85%); the middle value is on the limit's open side.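

In this assay compound 4 gives only a limit, > 250000 nM, and compound 2 sits at that same limit, so the step between them cannot be read: the limit of > 250000 nM in this assay, at which 4 of the 4 values shown sit.

The compounds shown leave open whether any change to the shared core gives a measurable value, and how large any of these steps is.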